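A few compounds are considered here, and "the series" means these few. Any claim that something is new, unique, unknown or untested is made for them only; others in the source may bear on it.

Measured so far in an assay on isolated protein for inhibition of Amine oxidase [flavin-containing] A (Homo sapiens), read by fluorescence, with a stated time of 30 min, tested at 20 uM; a lower number here means less inhibition, a higher number more inhibition at the concentration tested (going by the name of the read-out): compound 1 `COc1cc2c(cc1OC)C(=O)/C(=C/c1cccc(O)c1)CO2` gives 21.9%; compound 2 `COc1cc2c(cc1OC)C(=O)/C(=C/c1ccc(CN3CCCC3)c(O)c1)CO2` gives 16.4%; compound 3 `COc1cc2c(cc1OC)C(=O)/C(=C/c1ccc(CN3CCCCC3)c(O)c1)CO2` gives 24.6%.

On these numbers compound 3 holds the highest value of the three, but only nominally: its nearest neighbour is compound 1, with a number 2.7 percentage points higher from compound 1 to compound 3 (within the scatter), and its furthest is compound 2, with a number 8.2 percentage points higher from compound 2 to compound 3 (within the scatter), so all three compounds sit within the scatter of one another.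

Compound 4 `COc1cc2c(cc1OC)C(=O)/C(=C/c1ccc(CN(C)Cc3ccccc3)c(O)c1)CO2` differs from compound 3 at one place: benzyl(methyl)amino in place of piperidin-1-yl on a saturated chain carbon bound to an aromatic carbon. The step that bears most directly on this change is the exchange of one ring amine for another at the same saturated chain carbon, a number 8.2 percentage points higher from compound 2 to compound 3 (within the scatter), while the two additions of such a group to the bare aromatic carbon, a number 5.5 percentage points lower from compound 1 to compound 2 (within the scatter) and a number 2.7 percentage points higher from compound 1 to compound 3 (within the scatter), were equally small. Nothing in these steps points to a change beyond the scatter, so compound 4 is expected to give roughly the same number as compound 3, with a number 0.6 percentage points lower from compound 3 to compound 4 (within the scatter). The estimate for compound 4 in this assay is 24%, with a range from 10% to 40%.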

Compound 4, a percentage reported as inhibition, at one concentration (the size of the read-out at that concentration, not a potency): 3.4%
Estimate against measurement, compound 4: 20.6 percentage points above; measured number outside the range, below it.
By their numbers in this assay, from the lowest: compound 4; then compounds 2, 1 and 3 (each within the scatter of the next).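

In this assay this place on a saturated chain carbon bound to an aromatic carbon turns out not to be indifferent to the amine it carries: benzyl(methyl)amino in place of piperidin-1-yl gives a number 21.2 percentage points lower from compound 3 to compound 4 (beyond the scatter) and in place of pyrrolidin-1-yl gives a number 13 percentage points lower from compound 2 to compound 4 (beyond the scatter), whereas the exchange between the two ring amines stayed within the scatter. Of the three additions to the bare aromatic carbon, only (benzyl(methyl)amino)methyl gives a step beyond the scatter, with a number 18.5 percentage points lower from compound 1 to compound 4 (beyond the scatter) as its size. Nothing shown here accounts for this fall.

From the compounds shown here alone, whether it goes with the open-chain amine or with the six-membered aromatic ring of carbon only stays open. Dimethylamino and 4-phenylpiperidin-1-yl at the same place would separate the two.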